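A few compounds are considered here, and "the series" means these few. Any claim that something is new, unique, unknown or untested is made for them only; others in the source may bear on it.

Two stilbene-type compounds have been tested so far. Compound 1 `Nc1ccc(/C=C/c2ccccc2O)cc1` carries an amino group on one ring and a hydroxy group on the other. In an ADME assay on HEK293 cells (Homo sapiens) for inhibition, read by MTT assay, with a stated time of 2 days (on this read-out higher numbers stand for weaker inhibition and lower numbers for stronger inhibition), compound 1 gives 21.4 ug/mL. Compound 2 `COc1ccccc1/C=C/c1ccc(O)cc1` carries a methoxy group on one ring and a hydroxy group on the other, and in this assay compound 2 gives 41 ug/mL. The gap between these two numbers lies within the usual scatter of repeated measurements, so the two compounds cannot be told apart on what has been measured.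

Compound 3 `COc1ccccc1/C=C/c1ccc(N)cc1` has not yet been measured. It differs from compound 2 in one place: amino in place of hydroxy on an aromatic carbon. Within the data shown here, no measured pair shows this exact change, so nothing is known about its size here. Given how close the two measured numbers sit, the expectation is a step of a 1.4-fold lower number from compound 2 to compound 3 (0.14 log units; within the scatter), that is, none beyond the scatter. Compound 3 is therefore estimated at 30 ug/mL, with a range from 12 ug/mL to 75 ug/mL.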

Compound 3, half-maximal inhibitory concentration: 1 ug/mL
Compound 3: middle estimate off by 30-fold (1.48 log units), on the high side; the whole stated range lies above it.
By their numbers in this assay, from the lowest: compound 3; then compounds 1 and 2 (each within the scatter of the next).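

In this assay, amino in place of hydroxy at this position, para to a large group, gives a 41-fold lower number from compound 2 to compound 3 (1.61 log units; beyond the scatter) even though the count of heavy atoms, donors and acceptors stays the same. Methyl in place of hydrogen on the oxygen on the other ring also counts here, with a 21-fold lower number from compound 1 to compound 3 (1.33 log units; beyond the scatter) as the second large step. Compound 3 alone carries the amino and methoxy groups together, while compound 1 and compound 2, which each keep a hydroxy group, cannot be told apart, so neither change can be judged without regard to the group on the other ring.

Going by these compounds, whether a dimethylamino group at the amino position, or an ethyl group in place of the methyl on the oxygen, would keep the low number remains open. Nothing available explains why these steps are so large.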